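Ether substituent series on the fluorinated bicyclic core

This account rests on a few compounds, and the source may have more. Where it says the series, first, only, none or still open, it means among the compounds named here.

Compound 3 `N[C@]1(C(=O)O)[C@H]2[C@@H](C[C@H]1OCc1cccc(Br)c1)[C@]2(F)C(=O)O` gives the lowest number of the three measured in an assay on CHO cells for binding affinity to metabotropic glutamate receptor 2 (Rattus norvegicus) (on this read-out lower numbers stand for stronger inhibition and higher numbers for weaker inhibition), at 4.71 nM. Compound 2 `N[C@]1(C(=O)O)[C@H]2[C@@H](C[C@H]1OCCCc1ccccc1)[C@]2(F)C(=O)O` gives 9.83 nM and compound 1 `CO[C@@H]1C[C@@H]2[C@H]([C@]1(N)C(=O)O)[C@@]2(F)C(=O)O` gives 39.2 nM; the steps of a 4.0-fold lower number from compound 1 to compound 2 (0.60 log units; beyond the scatter), an 8.3-fold lower number from compound 1 to compound 3 (0.92 log units; beyond the scatter) and a 2.1-fold lower number from compound 2 to compound 3 (0.32 log units; beyond the scatter) all run toward lower numbers as hydrogen on the chain carbon bound to the ether oxygen gives way to phenethyl and then to 3-bromophenyl. Compound 4 `N[C@]1(C(=O)O)[C@H]2[C@@H](C[C@H]1OCc1cccc(Oc3ccccc3)c1)[C@]2(F)C(=O)O` differs from compound 3 by phenoxy in place of bromo on an aromatic carbon. Going by the values given here, no measured step alters a group on the six-membered aromatic ring itself, so the earlier steps bear only loosely, through their shared direction. The expectation for compound 4 in this assay is therefore a small step, a 1.3-fold lower number from compound 3 to compound 4 (0.13 log units; within the scatter), with no confident direction. Compound 4 is estimated at 3.5 nM, with a range from 1.2 nM to 12 nM.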

Compound 4, inhibition constant: 7.15 nM
Compound 4: middle estimate off by 2.0-fold (0.31 log units), on the low side; low and high end bracket the measured number.
By their numbers in this assay, from the lowest: compounds 3, 4 and 2 (each within the scatter of the next, the first and the last beyond it); then compound 1.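

In this assay, going by these compounds alone, the only step that alters a group on the aromatic ring itself is a 1.5-fold higher number from compound 3 to compound 4 (0.18 log units; within the scatter), so the two compounds cannot be told apart. On this aromatic carbon, phenoxy, with seven heavy atoms and an added aromatic ring, is accepted in place of the single bromine atom, at least for this pair. No measured evidence bears on why the two groups read alike.

Going by these compounds, whether an amine or a carboxylic acid on this carbon would read the same stays open. So does whether phenoxy would be accepted on other carbons of the ring.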